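Carbamoyl for Hydroxymethyl: Expected Clearance of Compound 3

The compounds below may be only part of what the source reports. "The series", "measured", "known", "first", "only" and "open" are said of these compounds alone.

Measured so far in an ADME assay (liver) for metabolic stability, with Liver microsome (Homo sapiens) as the target, read by LC-MS, using microsomes and NADPH, with a stated time of 5 min, at 37 degrees C; on this read-out higher numbers stand for fast clearance and lower numbers for slow clearance:
compound 1 `CCn1c([C@@H](C)NS(=O)(=O)c2ccc(Cl)cc2)nc2cc(C#N)ccc21` gives 71 mL.min-1.g-1
compound 2 `CCn1c([C@@H](C)NS(=O)(=O)c2ccc(Cl)cc2)nc2cc(CO)ccc21` gives 88 mL.min-1.g-1

Of these two numbers in this assay, that of compound 2 is the larger, but compound 1 at 71 mL.min-1.g-1 lies within the scatter of it, so no real order between the two can be claimed. Within the data shown here, the only measured step is a 1.2-fold higher number from compound 1 to compound 2 (0.09 log units; within the scatter), and it bears on the present question only loosely, since it exchanges cyano for hydroxymethyl rather than hydroxymethyl for carbamoyl. The unmeasured compound 3 `CCn1c([C@@H](C)NS(=O)(=O)c2ccc(Cl)cc2)nc2cc(C(N)=O)ccc21` differs from compound 2 in this way: carbamoyl in place of hydroxymethyl on an aromatic carbon. Among the measured compounds shown here, no measured pair exchanges these two groups at this position; the one step that does touch this position is within the scatter, and nothing measured points to a shift beyond it in either direction. Compound 3 is therefore expected to give, in this assay, about 70 mL.min-1.g-1, with a range from 35 mL.min-1.g-1 to 140 mL.min-1.g-1. The step this estimate means, a 1.3-fold lower number from compound 2 to compound 3 (0.10 log units; within the scatter), is expected to remain within the scatter.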

Compound 3, intrinsic clearance in microsomes: < 5 mL.min-1.g-1
Compound 3: only a limit was reported; the forecaster's own chance of this, stated with the estimate: 5%; middle value at least 14-fold (1.14 log units) away from the limit.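

In this assay, this aromatic carbon had so far shown no real separation between cyano and hydroxymethyl, with a 1.2-fold higher number from compound 1 to compound 2 (0.09 log units; within the scatter), and so gave no sign that a change here could matter much. Carbamoyl changes that picture: it gives an at least 17-fold lower number from compound 2 to compound 3 (1.24 log units; beyond the scatter), and the exchange for cyano tells the same story, with an at least 14-fold lower number from compound 1 to compound 3 (1.15 log units; beyond the scatter), so both steps lie beyond the scatter and this position proves highly sensitive to the group it carries. The reading for compound 3 is a limit of the assay and not a number, which means that the full size of both steps stays unknown: the limit of < 5 mL.min-1.g-1 in this assay, at which 1 of the 3 values shown sits.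

The compounds shown leave open whether the low reading belongs to carbamoyl alone or would also appear with a carboxylic acid, an amine or an N-methyl amide on this aromatic carbon. They also leave open whether carbamoyl in place of hydroxymethyl would give a step of this size if a longer chain were carried elsewhere on the shared core.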